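The compounds below may be only part of what the source reports. "The series", "measured", "known", "first", "only" and "open" are said of these compounds alone.

Measured compounds: compound 1 `CN(c1cccc(NC(=O)CN2N=C(C3CCCCC3)c3ccccc3N(CC(=O)C(C)(C)C)C2=O)c1)c1nn[nH]n1` with 24 nM in a functional assay on stomach for antagonist activity at Gastrin/cholecystokinin type B receptor (Rattus norvegicus); a higher number here means weaker binding, a lower number tighter binding; compound 2 `CC(C)(C)C(=O)CN1C(=O)N(CC(=O)Nc2cccc(-c3nc(=O)o[nH]3)c2)N=C(C2CCCCC2)c2ccccc21` with 9.55 nM; compound 3 `O=C(O)CSc1cccc(NC(=O)CN2N=C(C3CCCCC3)c3ccccc3N(CC(=O)C3CCCC3)C2=O)c1` with 1.48 nM.

Among these three, compound 2 stands second highest in this assay: compound 1 gives a number higher by a 2.5-fold lower number from compound 1 to compound 2 (0.40 log units; beyond the scatter), and compound 3 gives a number lower than compound 2 by an amount beyond the scatter. Compound 4 `CC(C)(C)C(=O)CN1C(=O)N(CC(=O)Nc2cccc(CCC(=O)O)c2)N=C(C2CCCCC2)c2ccccc21` is the unmeasured compound. It differs from compound 2 in one place: a group of 5 heavy atoms (3 carbon, 2 oxygen; no ring) in place of a group of 6 heavy atoms (2 carbon, 2 nitrogen, 2 oxygen; one five-membered aromatic ring with 3 hetero atoms), on an aromatic carbon.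

For the measured compounds named here, only one measured step touches the same position, the step from compound 1 to compound 2, which changed one five-membered ring for another and gave a 2.5-fold lower number from compound 1 to compound 2 (0.40 log units; beyond the scatter). Going by the values given here, no measured pair isolates the exchange of a five-membered ring for 2-carboxyethyl; compound 3 carries an open-chain acid on the same aromatic carbon but also differs elsewhere, so its value shows only that such a group is compatible with tight binding. The expected step from compound 2 to compound 4 in this assay is therefore a modest one, a 1.6-fold lower number from compound 2 to compound 4 (0.20 log units; within the scatter). Compound 4 is estimated at 6 nM, within a range of 1.5 nM to 25 nM.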

Compound 4, dissociation constant: 4.47 nM
For compound 4 the middle estimate is 1.3-fold (0.13 log units) above the measured one, and the stated range covers the measured number.
By their numbers in this assay, from the lowest: compound 3; then compound 4; then compound 2; then compound 1.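

In this assay, 2-carboxyethyl, which has no ring, took the place of the five-membered aromatic ring of compound 2 and gave a 2.1-fold lower number from compound 2 to compound 4 (0.33 log units; beyond the scatter) and so this aromatic carbon does not need a ring for the number to fall. Set against the (2H-tetrazol-5-yl)(methyl)amino group, the same chain gave a 5.4-fold lower number from compound 1 to compound 4 (0.73 log units; beyond the scatter) and thus stands with a lower number than both ring-bearing groups in this series. No measurement here accounts for this order.

The compounds shown leave open how the number responds to chain length, for instance with a carboxylic acid joined directly to the aromatic ring or with a longer chain ending in one. They also leave open whether the acid itself is needed, which a primary amide or an amine at the end of the same chain would test.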